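Compound 3 and the group on the double-bonded nitrogen

A few compounds are considered here, and "the series" means these few. Any claim that something is new, unique, unknown or untested is made for them only; others in the source may bear on it.

In a functional assay for inhibition, with Rattus norvegicus as the target (on this read-out lower numbers stand for stronger inhibition and higher numbers for weaker inhibition), compound 1 `CCC(CC)/N=c1\c(O)c(O)\c1=N/c1ccc(C#N)cc1` gives 3340 nM. Compound 2 `C/N=c1\c(O)c(O)\c1=N/c1ccc(C#N)cc1` reaches only a limit of the assay, > 30000 nM. Compound 3 `C[C@@H](/N=c1\c(O)c(O)\c1=N/c1ccc(C#N)cc1)c1ccccc1` has 1-phenylethyl in place of methyl on a double-bonded nitrogen. Within the data shown here, the one measured step at this place, with methyl in place of pentan-3-yl, is an at least 8.9-fold higher number from compound 1 to compound 2 (0.95 log units; beyond the scatter). Compound 3 reverses that kind of exchange, so a number nearer that of compound 1 at 3340 nM is expected. The estimated change is an at least 15-fold lower number from compound 2 to compound 3 (1.17 log units; beyond the scatter), towards a lower number. Compound 3 is expected at 2000 nM, with an estimated range of 400 nM to 10000 nM.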

Compound 3, half-maximal inhibitory concentration: 56 nM
Compound 3: middle estimate off by 36-fold (1.55 log units), on the high side; measured number outside the range, below it.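

With 1-phenylethyl in place of pentan-3-yl, this assay shows a 60-fold lower number from compound 1 to compound 3 (1.78 log units; beyond the scatter), so a group carrying an aromatic ring on the double-bonded nitrogen goes well beyond what the branched chain reached. Set against methyl, 1-phenylethyl gives an at least 530-fold lower number from compound 2 to compound 3 (2.72 log units; beyond the scatter). That step is only a bound: the limit of > 30000 nM in this assay, at which 1 of the 3 values shown sits. The compounds shown leave open whether the aromatic ring itself matters, which a cyclohexyl-bearing 1-cyclohexylethyl group would test, and whether a plain benzyl group would do as well. Going by these compounds, the mirror-image 1-phenylethyl group also remains open.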